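The compounds below may be only part of what the source reports. "The series", "measured", "known", "first", "only" and "open" are said of these compounds alone.

Measured in a functional assay on NCI-H441 cells (Homo sapiens) for antiproliferative activity, with a stated time of 24 h; a lower number here means a stronger inhibitor, a higher number a weaker inhibitor:
- compound 1 `OC1/C(=C/c2ccccc2F)CNC/C1=C\c1ccccc1F`: 124000 nM
- compound 2 `O=C1C(Cc2ccccc2F)CNCC1Cc1ccccc1F`: 130000 nM
- compound 3 `O=C(O)CCC(=O)N1C/C(=C\c2ccccc2F)C(=O)/C(=C/c2ccccc2F)C1`: 69000 nM

Compound 3 gives 69000 nM in this assay. That value lies within the usual scatter of repeated measurements from those of both other compounds, so the three numbers cannot be told apart and compound 3 has no clear rank among them.

The next compound is compound 4 `O=C(O)/C=C/C(=O)N1C/C(=C\c2ccccc2F)C(=O)/C(=C/c2ccccc2F)C1`. It differs from compound 3 in one place: 2-carboxyethenyl stands in place of 2-carboxyethyl, on a carbonyl carbon whose other neighbours are an amide-type nitrogen in a ring (2-carboxyethenyl in place of 2-carboxyethyl on a carbonyl carbon). Cut one bond further out, this is (2-carboxyethenyl)carbonyl in place of (2-carboxyethyl)carbonyl.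

Among the compounds with values here, no pair of measured compounds differs in only one place, so the data give no direct guide to the size of such a step. Within the data shown here, the only hint is that compound 1 at 124000 nM and compound 3 at 69000 nM stay within the scatter despite their different structures. A small change is therefore expected, perhaps towards a slightly lower number, but nothing beyond the scatter. The estimated step is a 1.3-fold lower number from compound 3 to compound 4 (0.10 log units; within the scatter). For compound 4 the estimated value is 55000 nM, with an expected range from 18000 nM to 130000 nM.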

Compound 4, half-maximal inhibitory concentration: 29000 nM
The estimate for compound 4 lay 1.9-fold (0.28 log units) above the measured number; the measured number falls inside the stated range.
By their numbers in this assay, from the lowest: compound 4; then compounds 3, 1 and 2 (each within the scatter of the next).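

In this assay, within the data shown here, the change on this carbonyl carbon is the first single-place comparison that can be read, and it gives a 2.4-fold lower number from compound 3 to compound 4 (0.38 log units; beyond the scatter) and so a modest shift beyond the usual scatter. The group that enters, 2-carboxyethenyl, has the same count of heavy atoms, hydrogen-bond donors and hydrogen-bond acceptors as 2-carboxyethyl, the group that leaves, and differs in these counts only by one more double bond outside aromatic rings, so a difference this small in the chain is enough to move the number at this position. No measurement on these compounds explains the shift.

The compounds shown leave open whether the lower number follows from the double bond alone or depends on the carboxylic acid at the end of the chain, which a methyl ester or a primary amide in its place would help to separate. Going by these compounds, it also remains open how the number would respond to a longer chain with a double bond, or to an amine at the end of the chain.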